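Branching the propyl chain: from compound 3 to compound 4

The source may hold more compounds than are shown below. What is called first, only, known or untested is meant among the compounds shown, and "the series" means these compounds.

Measured so far:
compound 1 `O=C(O)c1ccccc1-c1ccc(CCc2ncc(Cc3cccc(Cl)c3)[nH]2)cc1` gives 31 nM in an in vitro functional assay on cells for agonist activity at Bombesin receptor subtype-3 (Mus musculus), read by luminescence and calcium flux; on this read-out lower numbers stand for an effect already at smaller amounts and higher numbers for an effect only at larger amounts of compound
compound 2 `O=C(O)c1ccccc1-c1ccc(CCc2ncc(CC3CCCCCC3)[nH]2)cc1` gives 5.7 nM in this assay
compound 3 `CCCCc1cnc(CCc2ccc(-c3ccccc3C(=O)O)cc2)[nH]1` gives 93 nM in this assay

Of these three, compound 3 stands at the highest number in this assay. Its step from compound 1 is a 3.0-fold higher number from compound 1 to compound 3 (0.48 log units; beyond the scatter), and from compound 2 it is a 16-fold higher number from compound 2 to compound 3 (1.21 log units; beyond the scatter); both are beyond the scatter, so compound 3 is the weakest of the measured set.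

Compound 4 `CC(C)CCc1cnc(CCc2ccc(-c3ccccc3C(=O)O)cc2)[nH]1` is not yet measured. It differs from compound 3 by methyl in place of hydrogen on a saturated chain carbon bound to two saturated chain carbons. The propyl chain of compound 3 thus becomes an isobutyl chain.

Among the measured compounds shown here, the steps that bear on this position all involve exchanging the whole group on the saturated chain carbon bound to an aromatic carbon: a 5.4-fold lower number from compound 1 to compound 2 (0.74 log units; beyond the scatter), a 3.0-fold higher number from compound 1 to compound 3 (0.48 log units; beyond the scatter) and a 16-fold higher number from compound 2 to compound 3 (1.21 log units; beyond the scatter). In every case the propyl of compound 3 gave the highest number, while the cycloheptyl of compound 2 gave the lowest. Adding one methyl is a far smaller change than any of these exchanges, so only a modest movement is expected. For compound 4, a number somewhat below that of compound 3 is estimated, a step of a 1.9-fold lower number from compound 3 to compound 4 (0.27 log units; within the scatter), because compound 3 sits at 93 nM with the smallest group of the set. The estimate for compound 4 is 50 nM, within a range of 20 nM to 150 nM.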

Compound 4, half-maximal effective concentration: 10 nM
The estimate for compound 4 lay 5.0-fold (0.70 log units) above the measured number; the measured number lies below the stated range.
By their numbers in this assay, from the lowest: compounds 2 and 4 (each within the scatter of the next); then compound 1; then compound 3.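

In this assay, among the compounds shown here, turning the propyl into an isobutyl by adding a single methyl on a saturated chain carbon bound to two saturated chain carbons gives a 9.3-fold lower number from compound 3 to compound 4 (0.97 log units; beyond the scatter) and so shows that this position responds strongly to a one-atom change, whereas the earlier steps exchanged the whole group. Isobutyl in place of cycloheptyl gives a 1.8-fold higher number from compound 2 to compound 4 (0.24 log units; within the scatter) and lies within the scatter, so a ring is not needed to reach the low end of this set, and isobutyl in place of 3-chlorophenyl gives a 3.1-fold lower number from compound 1 to compound 4 (0.49 log units; beyond the scatter) and goes against any reading that the group with fewer atoms gives the higher number, since compound 4 carries fewer atoms here than compound 1 yet has the lower number. Nothing shown here explains why this one methyl has so large an effect.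

On these data alone, whether a second branch, as in a tert-butyl group, would move the number further remains open, and so does the effect of a longer chain such as hexyl. An amine or a hydroxyl on the chain is also untested in what is shown, so it is unknown whether this position accepts anything other than carbon and hydrogen.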